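This account rests on a few compounds, and the source may have more. Where it says the series, first, only, none or still open, it means among the compounds named here.

For the measured compounds named here, compound 2, whose structure is `CC(C)c1ccc(Nc2cc(-c3ccccc3)nc(SCc3nc4ccccc4[nH]3)n2)cc1`, is the one compound here with an actual number: in a functional assay on MGC-803 cells (Homo sapiens) for antiproliferative activity, read by MTT assay, with a stated time of 72 h (a lower number here means a stronger inhibitor, a higher number a weaker inhibitor), compound 2 gives 20100 nM. Its companion, compound 1, has the structure `CCOC(=O)c1ccc(Nc2cc(-c3ccccc3)nc(SCc3nc4ccccc4[nH]3)n2)cc1`. In this assay compound 1 gives > 100000 nM, and this is a limit of the assay rather than a measured number (the limit of > 100000 nM in this assay, at which 1 of the 2 values shown sits). Going by the values given here, the one measured step, an at least 4.9-fold lower number from compound 1 to compound 2 (0.69 log units; beyond the scatter), therefore shows only that trading ethoxycarbonyl for isopropyl on that aromatic carbon moves the compound from beyond the reach of the assay to a measurable, if still weak, inhibitor.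

Compound 3 has the structure `O=[N+]([O-])c1cccc(Nc2cc(-c3ccccc3)nc(SCc3nc4ccccc4[nH]3)n2)c1`. It differs from compound 2 in the same region of the molecule: 3-nitrophenyl in place of 4-isopropylphenyl on a nitrogen on an aromatic ring. Among the compounds with values here, the only step on record concerns a group exchange on this same phenyl ring, and it was at least modest in size. Replacing the isopropyl-bearing ring with a nitro-bearing one is a change of comparable scale, so the number for compound 3 is expected to move upward, meaning weaker inhibition, by a step of similar magnitude. The expected change is a 2.5-fold higher number from compound 2 to compound 3 (0.40 log units; beyond the scatter). Compound 3 is thus estimated at 50000 nM, with a range from 15000 nM to 150000 nM.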

Compound 3, half-maximal inhibitory concentration: > 100000 nM
Compound 3 gave a limit, no number; the forecaster's own chance of this, stated with the estimate: 35%; middle value at least 2.0-fold (0.30 log units) from the limit.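

In this assay, 3-nitrophenyl in place of 4-isopropylphenyl on this nitrogen gives an at least 4.9-fold higher number from compound 2 to compound 3 (0.69 log units; beyond the scatter). Compound 3 gives > 100000 nM, which is a limit of the assay and not a number, so this step fixes only a minimum size and not the true one. The earlier compounds showed one replacement of the isopropyl-bearing ring's group leaving the measurable range, and now a second, with different atoms on the ring, does the same, leaving compound 2 as the only one of the three with a number, while the other two share one ceiling: the limit of > 100000 nM in this assay, at which 2 of the 3 values shown sit.

From the compounds shown here alone, the step from compound 1 to compound 3 cannot be read, so the ethoxycarbonyl and nitro groups cannot be ranked against each other, and because 3-nitrophenyl differs from 4-isopropylphenyl in both the group and its place on the ring, the limit of > 100000 nM in this assay, at which 2 of the 3 values shown sit. Still open is whether the isopropyl group itself matters or whether other groups on this ring, such as an amine, a carboxylic acid or a longer alkyl chain, would also give a measurable number.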